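Swapping Chloro for Phenyl on a Salicylanilide Core

The source may hold more compounds than are shown below. What is called first, only, known or untested is meant among the compounds shown, and "the series" means these compounds.

Measured so far:
- compound 1, `O=C(Nc1cc(C(F)(F)F)cc(C(F)(F)F)c1)c1cc(Cl)c(-c2ccccc2)cc1O`: 540 nM
- compound 2, `O=C(Nc1cc(C(F)(F)F)cc(C(F)(F)F)c1)c1cc(Br)ccc1O`: 350 nM
- compound 3, `O=C(Nc1cc(C(F)(F)F)cc(C(F)(F)F)c1)c1ccc(Cl)cc1O`: 570 nM

All three compounds share a trifluoromethyl-bearing aniline joined through an amide to a hydroxyl-substituted aromatic ring, and each was tested in a functional assay on Jurkat cells (Homo sapiens) for cytotoxicity, read by luminescence and CellTiter-Glo, with a stated time of 3 days; a higher number here means a weaker inhibitor, a lower number a stronger inhibitor. Compound 3 gives 570 nM, the highest of the three numbers, yet its gaps to compound 1 and to compound 2 both sit within the usual scatter, so no ordering among them can be claimed.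

Compound 4, `O=C(Nc1cc(C(F)(F)F)cc(C(F)(F)F)c1)c1ccc(-c2ccccc2)cc1O`, has not yet been measured. It differs from compound 3 in one place: phenyl in place of chloro on an aromatic carbon.

Among the compounds with values here, only one measured step exists, a 1.6-fold higher number from compound 2 to compound 3 (0.21 log units; within the scatter), and it concerns a halogen moving position, not a phenyl entering, so it bears little on the change at hand. Compound 1 carries both a chloro and a phenyl on its hydroxyl-bearing ring and gives 540 nM, close to compound 3. Taken together, no step beyond the scatter is expected in this assay. Compound 4 is therefore estimated at 500 nM, within a range of 250 nM to 1000 nM, which would mean an expected step of a 1.1-fold lower number from compound 3 to compound 4 (0.06 log units; within the scatter).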

Compound 4, half-maximal inhibitory concentration: 1240 nM
Estimate against measurement, compound 4: 2.5-fold (0.39 log units) below; the measured number lies above the stated range.
By their numbers in this assay, from the lowest: compounds 2, 1 and 3 (each within the scatter of the next); then compound 4.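

In this assay, within the data shown here, phenyl in place of chloro at this position, meta to a hydroxy group and para to a large group, gives a 2.2-fold higher number from compound 3 to compound 4 (0.34 log units; beyond the scatter) and is the first change in this small set to clear the scatter. Compound 1 carries the same phenyl along with a chloro, and hydrogen in place of that chloro gives a 2.3-fold higher number from compound 1 to compound 4 (0.36 log units; beyond the scatter) in the same direction, so the phenyl alone does not fix the number: the chloro on the ring of compound 1 matters as well. Nothing measured here explains either step.

Going by these compounds, whether a methyl, an amine or a carboxylic acid at this position would behave like the chloro of compound 3 or the phenyl of compound 4 stays open. So does whether these steps would hold in cells other than Jurkat.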